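The compounds below may be only part of what the source reports. "The series", "measured", "known", "first", "only" and "open" are said of these compounds alone.

Compound 1 `O=S(=O)(Nc1ccc2oc(-c3ccccc3)nc2c1)c1ccccc1F` in an assay on isolated protein for inhibition of malate dehydrogenase, mitochondrial (Sus scrofa), with stated times of 45 min and 30 min (a lower number here means a stronger inhibitor, a higher number a weaker inhibitor), gives > 63000 nM, a limit of the assay and not a number.
Compound 2 `COc1ccc(Cl)cc1S(=O)(=O)Nc1ccc2oc(-c3ccccc3)nc2c1` in this assay gives > 63000 nM, likewise a limit.

Compound 1 therefore stands only at a limit in this assay, where both values shown sit (the limit of > 63000 nM in this assay, at which 2 of the 2 values shown sit). For the measured compounds named here, the one measured step, a step that the two limits leave unreadable from compound 1 to compound 2, carries no readable size. Compound 3 `O=S(=O)(Nc1ccc2oc(-c3ccccc3)nc2c1)c1ccccc1C(F)(F)F` differs from compound 1 by trifluoromethyl in place of fluoro on an aromatic carbon. Going by the values given here, no measured step bears on this change with a readable size, so the step that the limit leaves unreadable from compound 1 to compound 3 is expected to leave compound 3 at or beyond the same limit rather than show any shift beyond the scatter. Compound 3 is accordingly estimated at 100000 nM, within 30000 nM to 400000 nM, most likely reported again only as a limit.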

Compound 3, half-maximal inhibitory concentration: > 63000 nM
Compound 3: a limit, no number; the forecaster's own chance of this, stated with the estimate: 80%; the middle value lies beyond the limit too.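

No step can be read between compound 1 and compound 3, since each stands only at a limit of the assay: the limit of > 63000 nM in this assay, at which 3 of the 3 values shown sit. The compounds shown leave open what change, if any, would bring a measurable value in this assay.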